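Propyl to isobutyl on the sulfonamide side chain

The compounds below may be only part of what the source reports. "The series", "measured", "known", "first", "only" and "open" are said of these compounds alone.

Measured compounds:
Compound 1 `CCCNS(=O)(=O)c1ccc(Nc2ncc3c(n2)N(C2CCCC2)[C@H](CC)C(=O)N3C)cc1`: 548 nM
Compound 2 `CCCCNS(=O)(=O)c1ccc(Nc2ncc3c(n2)N(c2ccn(C)n2)C(CC)C(=O)N3C)cc1`: 4240 nM
Compound 3 `CCC1C(=O)N(C)c2cnc(Nc3ccc(S(=O)(=O)NCCO)cc3)nc2N1c1ccn(C)n1`: no number reported

Three compounds share one core and differ in the group on the core and the sulfonamide side chain. In a functional assay on K562 cells (Homo sapiens) for antiproliferative activity, read by CCK-8 assay, with a stated time of 72 h (a higher number here means a weaker inhibitor of growth, a lower number a stronger inhibitor of growth), compound 1 gives 548 nM, the lowest of the two numbers reported. Compound 2 gives 4240 nM, a gap from compound 1 that lies beyond the usual scatter. Compound 3 is reported in this assay as "not active" (no number reported), with no number attached.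

The unmeasured compound 4 `CC[C@@H]1C(=O)N(C)c2cnc(Nc3ccc(S(=O)(=O)NCC(C)C)cc3)nc2N1C1CCCC1` keeps the core and the group of compound 1 and changes only the side chain: methyl in place of hydrogen on a saturated chain carbon bound to two saturated chain carbons. Among the measured compounds shown here, no measured pair here shows what a single change of this kind does, so the expected step is small, in no clear direction, and not beyond the scatter. Compound 4 is therefore expected to sit close to compound 1, with an estimated step of a 1.0-fold higher number from compound 1 to compound 4 (0.00 log units; within the scatter). The estimate for compound 4 is 550 nM, within a range from 200 nM to 1600 nM.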

Compound 4, concentration for 50% growth inhibition: 705 nM
Compound 4: middle estimate off by 1.3-fold (0.11 log units), on the low side; the measured number falls inside the stated range.
By their numbers in this assay, from the lowest: compounds 1 and 4 (each within the scatter of the next); then compound 2.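

In this assay, among the compounds shown here, the pair of compound 1 and compound 4 gives the first reading of a single change in this set: a 1.3-fold higher number from compound 1 to compound 4 (0.11 log units; within the scatter), so the two compounds cannot be told apart. With the core and the cyclopentyl group held fixed, this side chain therefore takes a methyl in place of hydrogen on a saturated chain carbon bound to two saturated chain carbons with no step beyond the scatter, although this one pair cannot establish a wider pattern. No measurement shown here offers an explanation for this result.

On these data alone, whether a longer chain, an amine or a carboxylic acid on this side chain would keep the number close to that of compound 1 remains open. So does whether the same methyl would give a similar step with the methylpyrazole group of compound 2 on the core.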